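Swapping vinyl for phenoxy on a four-membered ring

A few compounds are considered here, and "the series" means these few. Any claim that something is new, unique, unknown or untested is made for them only; others in the source may bear on it.

Going by the values given here, in a functional assay on MCF7 cells (Homo sapiens) for inhibition, read by resazurin assay, with a stated time of 72 h (a lower number here means a stronger inhibitor, a higher number a weaker inhibitor), compound 2 `C=CC1C(=O)N(c2cc(OC)c(OC)c(OC)c2)C1c1ccc(SC)cc1` gives 51 nM, the lower of the two numbers so far and clearly apart from compound 1 `CCSc1ccc(C2C(Oc3ccccc3)C(=O)N2c2cc(OC)c(OC)c(OC)c2)cc1` at 210 nM. Compound 3 `COc1cc(N2C(=O)C(Oc3ccccc3)C2c2ccc(SC)cc2)cc(OC)c1OC` differs from compound 2 in one place: phenoxy in place of vinyl on a saturated ring carbon. Compound 1 also carries phenoxy, and its 210 nM points to a weaker inhibitor in this assay. The expected change is a 2.5-fold higher number from compound 2 to compound 3 (0.41 log units; beyond the scatter), a moderate step upward. For compound 3 the estimated value is 130 nM, with an expected range of 45 nM to 380 nM.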

Compound 3, half-maximal inhibitory concentration: 152 nM
Estimate against measurement, compound 3: 1.2-fold (0.07 log units) below; the range from low to high includes it.
By their numbers in this assay, from the lowest: compound 2; then compounds 3 and 1 (each within the scatter of the next).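

In this assay, this carbon of the four-membered ring responds to the group it carries: phenoxy in place of vinyl gives a 3.0-fold higher number from compound 2 to compound 3 (0.47 log units; beyond the scatter). With phenoxy in place, the sulfur chain matters little so far: hydrogen in place of methyl on the saturated chain carbon bound to the sulfur gives a 1.4-fold lower number from compound 1 to compound 3 (0.14 log units; within the scatter), so methylsulfanyl and ethylsulfanyl cannot be told apart here. Nothing available explains the step from vinyl to phenoxy. On these data alone, whether a methoxy group or an amine on this ring carbon would keep the number near that of compound 2 remains open.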